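Swapping a Trifluoromethylbenzyl Group for Phenoxy: Cytotoxicity Outlook

The source may hold more compounds than are shown below. What is called first, only, known or untested is meant among the compounds shown, and "the series" means these compounds.

Measured so far:
- compound 1 `COc1ccc(Oc2ccc3c(NCCCNCc4cc(F)ccc4OC)ccnc3c2)cc1`: 7000 nM
- compound 2 `COc1ccc(F)cc1CNCCCNc1ccnc2cc(Cc3cccc(C(F)(F)F)c3)ccc12`: 440 nM

These two compounds share one core and were compared in an ADME assay on HepG2 cells (Homo sapiens) for cytotoxicity, read by luminescence, CellTiter-Glo and ATP content, with a stated time of 72 h; a higher number here means that more compound is needed for the effect, a lower number that less compound is needed. Compound 2 stands at the lower of the two numbers, so it needs less compound for the effect than compound 1. Going by the values given here, the only measured step, a 16-fold lower number from compound 1 to compound 2 (1.20 log units; beyond the scatter), was large and went downward.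

Compound 3 `COc1ccc(F)cc1CNCCCNc1ccnc2cc(Oc3ccccc3)ccc12` is not yet measured. It differs from compound 2 in one place: phenoxy in place of 3-(trifluoromethyl)benzyl on an aromatic carbon. The group that enters, phenoxy, is an aryl ether like the 4-methoxyphenoxy of compound 1, while the group that leaves is the 3-(trifluoromethyl)benzyl that compound 2 carries. The step from compound 1 to compound 2 therefore bears directly on this change, and it was well beyond the scatter. Because a 16-fold lower number from compound 1 to compound 2 (1.20 log units; beyond the scatter) was seen when the ether was exchanged for the benzyl group, the reverse kind of exchange in compound 3 is expected to move the number back upward, though perhaps not all the way, since the entering group lacks the methoxy of compound 1. The expected step is a 6.8-fold higher number from compound 2 to compound 3 (0.83 log units; beyond the scatter). Compound 3 is thus estimated at 3000 nM, with a range from 1000 nM to 10000 nM.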

Compound 3, half-maximal effective concentration: 1500 nM
For compound 3 the middle estimate is 2.0-fold (0.30 log units) above the measured one, and the stated range covers the measured number.
By their numbers in this assay, from the lowest: compound 2; then compound 3; then compound 1.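

Compound 3 splits the large drop seen earlier into two smaller parts, each beyond the scatter. Going by these compounds alone, with only the methoxy group removed from the aryl ether, the measurements in this assay show a 4.7-fold lower number from compound 1 to compound 3 (0.67 log units; beyond the scatter) and so give the first reading of that single group. Exchanging the bare phenoxy group for 3-(trifluoromethyl)benzyl at the same aromatic carbon still matters, as a 3.4-fold higher number from compound 2 to compound 3 (0.53 log units; beyond the scatter) shows when read in reverse, so the benzyl compound keeps the lowest number even against an ether without the methoxy group.

As far as these compounds go, whether an unsubstituted benzyl group, an amine or a carboxylic acid at this aromatic carbon would fall nearer to compound 2 or to compound 3 stays open, which leaves unsettled how much of the change belongs to the trifluoromethyl group and how much to the ether or benzyl link. Nothing available explains why either exchange moves the number in this way.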